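Compound 1 to Compound 4: A Step Down from the Limit

The source may report more compounds than this note shows. Statements on the series, on what has been measured and on what is new or still open speak of the compounds shown alone.

In a physicochemical assay for solubility, read by nephelometry, measured as kinetic solubility, at pH 2.0 (on this read-out higher numbers stand for higher solubility and lower numbers for lower solubility), compound 1, `CC(C)(C)c1cc(C(=O)Nc2cccc(CN)c2)n(Cc2ccccc2)n1`, gives > 100 ug/mL, which is a limit of the assay and not a number. Compound 2, `NCc1csc(NC(=O)c2cnnn2Cc2ccccc2)n1`, gives > 100 ug/mL, also a limit. Compound 3, `NCc1csc(NC(=O)c2ccn[nH]2)n1`, gives > 100 ug/mL, again a limit. The measurements so far therefore come to one shared position: the limit of > 100 ug/mL in this assay, at which 3 of the 3 values shown sit. Compound 1 thus stands with the other two, and none of the three can be ranked against another.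

Compound 4, `CC(C)(C)c1cc(C(=O)Nc2cccnc2)n(Cc2ccccc2)n1`, has pyridin-3-yl in place of 3-(aminomethyl)phenyl on an amide-type nitrogen. Among the measured compounds shown here, no two measured compounds differ in one place, so no measured step offers a guide to its size. Each of the three measured compounds carries an aminomethyl group, and compound 4 does not. On that structural change, a moderate fall in this assay is expected, although compound 4 may yet remain at the limit. Compound 1 sits at > 100 ug/mL, a limit that leaves the size of any fall uncertain. The estimated change is an at least 1.6-fold lower number from compound 1 to compound 4 (0.22 log units; that floor lies within the scatter). For compound 4 the expected value is 60 ug/mL, with an estimated range from 20 ug/mL to 100 ug/mL.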

Compound 4, solubility: > 100 ug/mL
Compound 4 was reported as a limit; the forecaster's own chance of this, stated with the estimate: 35%; middle value at least 1.6-fold (0.22 log units) away from the limit.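

In this assay compound 4 gives > 100 ug/mL, which is a limit of the assay and not a number. Among the compounds shown here, compound 1 also stands at a limit, so no step between compound 1 and compound 4 can be read. The compounds shown leave open how any one of them ranks against another, and how far each lies past the shared position: the limit of > 100 ug/mL in this assay, at which 4 of the 4 values shown sit.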